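The compounds below may be only part of what the source reports. "The series", "measured", "known", "first", "only" and "open" are said of these compounds alone.

Measured so far in a functional assay on Ehrlich cells (Mus musculus) for cytotoxicity, read by trypan blue exclusion, with a stated time of 2 h, tested at 100 ug/mL; a lower number here means a weaker effect, a higher number a stronger effect of the compound at the concentration tested:
compound 1, `N#CC1=C(NC(=O)C2CC2)N(c2ccc(S(N)(=O)=O)cc2)C2=C(C(=O)CCC2)C1c1ccc(Cl)cc1Cl`, gives 60%
compound 2, `NC(=O)C1=C(N)N(c2ccc(S(N)(=O)=O)cc2)C2=C(C(=O)CCC2)C1c1ccc(Cl)cc1Cl`, gives 45%
compound 3, `CN(C)c1ccc(/C=C/C=N/C2=C(C#N)C(c3ccc(Cl)cc3Cl)C3=C(CCCC3=O)N2c2ccc(S(N)(=O)=O)cc2)cc1`, gives 20%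

All three compounds share one core and are read in this assay as the share of cells that take up the dye, so the number describes how strongly the cells are hit at the one concentration tested: a higher number means a stronger and a lower number a weaker effect at that concentration. Compound 1 stands highest of the three numbers. Compound 2 lies below it by a gap that is beyond the usual scatter, and compound 3 lies furthest below, also beyond the scatter.

The next compound, compound 4, `CCO/C=N/C1=C(C#N)C(c2ccc(Cl)cc2Cl)C2=C(CCCC2=O)N1c1ccc(S(N)(=O)=O)cc1`, has not yet been measured. Going by the values given here, it differs from compound 1 in a single place: a group of 5 heavy atoms (3 carbon, 1 nitrogen, 1 oxygen; no ring) in place of a group of 6 heavy atoms (4 carbon, 1 nitrogen, 1 oxygen; one three-membered non-aromatic ring of carbon only), on a double-bonded ring carbon No measured pair of compounds repeats this exact change, so the size of the step can only be expected, not read off.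

The expectation is a fall beyond the scatter, as a step of a number 25 percentage points lower from compound 1 to compound 4 (beyond the scatter) from compound 1. Compound 4 is estimated at 35%, with a range from 15% to 55%.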

Compound 4, a percentage reported as activity, at one concentration (the size of the read-out at that concentration, not a potency): 40%
Compound 4: the middle estimate sits 5 percentage points below what was measured; the range from low to high includes it.
By their numbers in this assay, from the lowest: compound 3; then compounds 4 and 2 (each within the scatter of the next); then compound 1.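

In this assay, replacing the (cyclopropylcarbonyl)amino group on the double-bonded ring carbon with the ethoxy-bearing group, which has no ring and no hydrogen-bond donor, gives a number 20 percentage points lower from compound 1 to compound 4 (beyond the scatter) and shows that the read-out responds to a change at this position. On the carbon with a double bond to nitrogen, ethoxy in place of 2-(4-(dimethylamino)phenyl)ethenyl gives a number 20 percentage points higher from compound 3 to compound 4 (beyond the scatter), so the group at the end of this attachment also matters. Compound 4 thus links compound 1 and compound 3 through two single changes, each beyond the scatter.

Nothing measured here explains either step. On these data alone, it remains open whether a methoxy group or a longer chain such as butoxy in place of the ethoxy, or an acetylamino group in place of the (cyclopropylcarbonyl)amino group, would move the read-out.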